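Aryl chloride removal on a benzamide analogue in the series

The source may hold more compounds than are shown below. What is called first, only, known or untested is meant among the compounds shown, and "the series" means these compounds.

Measured compounds:
compound 1 `C#CCNC1CCc2c(OCCc3cc(NC(C)=O)ccc3Cl)cccc21` — in an assay on cells for inhibition of Amine oxidase [flavin-containing] B (Homo sapiens), read by fluorescence and Amplex Red, with stated times of 30 min and 15 min (a higher number here means a weaker inhibitor, a lower number a stronger inhibitor), compound 1 gives 590 nM
compound 2 `C#CCNC1CCc2c(OCCc3cc(NC(=O)c4ccc(Cl)cc4)ccc3Cl)cccc21` — in this assay compound 2 gives > 20000 nM
compound 3 `C#CCNC1CCc2c(OCCc3cc(NC(=O)CO)ccc3Cl)cccc21` — in this assay compound 3 gives 270 nM

The value for compound 2 is a limit of this assay, not a number; it sits at the limit of > 20000 nM in this assay, at which 1 of the 3 values shown sits. Of the three compounds, compound 2 therefore stands at the weak end of what has been seen. The steps measured so far all change the group on the carbonyl carbon of the amide: an at least 33-fold higher number from compound 1 to compound 2 (1.53 log units; beyond the scatter) and an at least 74-fold lower number from compound 2 to compound 3 (1.86 log units; beyond the scatter) are large, while a 2.2-fold lower number from compound 1 to compound 3 (0.34 log units; beyond the scatter) is modest.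

Compound 4 `C#CCNC1CCc2c(OCCc3cccc(NC(=O)c4ccc(Cl)cc4)c3)cccc21` differs from compound 2 by hydrogen in place of chloro on an aromatic carbon. Among the measured compounds shown here, none of the measured steps touches this aromatic chloro, so no step bears directly on it; the amide side chain of compound 4, the 4-chlorophenyl on the carbonyl carbon, is the one that gave the weakest value. For the measured compounds named here, with no precedent for the change itself, compound 4 is expected to stay near the weak end, and the step of a number no higher from compound 2 to compound 4 (the limit leaves the size open) is estimated to lie within the scatter. The estimate for compound 4 in this assay is 20000 nM, with a range from 4000 nM to 80000 nM.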

Compound 4, half-maximal inhibitory concentration: 360 nM
For compound 4 the middle estimate is 56-fold (1.74 log units) above the measured one; the measured number lies below the stated range.
By their numbers in this assay, from the lowest: compounds 3, 4 and 1 (each within the scatter of the next, the first and the last beyond it). At a limit, above all of these: compound 2.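

In this assay, the chloro ortho to a large group and para to a ((4-chlorophenyl)carbonyl)amino group proves decisive for this amide, and hydrogen in its place gives an at least 55-fold lower number from compound 2 to compound 4 (1.74 log units; beyond the scatter) in this pair. The earlier steps shown here all changed the group on the carbonyl carbon and pointed to the 4-chlorophenyl as the source of the loss, yet compound 4 gives 360 nM while carrying that same group, so the 4-chlorophenyl amide is compatible with a measurable value once the chloro is gone and the effect of the amide group depends on what stands at this aromatic carbon. The size of the step has no upper bound, since compound 2 gives > 20000 nM, which is a limit of the assay and not a number: the limit of > 20000 nM in this assay, at which 1 of the 4 values shown sits.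

Still open, as far as these compounds go, is whether hydrogen in place of chloro changes the value in the same way with methyl or hydroxymethyl on the carbonyl carbon, where the chloro-bearing compounds already sit at much lower numbers. Also open, from the compounds shown here alone, is whether fluoro, methyl or methoxy at this aromatic carbon reads like chloro or like hydrogen when the 4-chlorophenyl amide is present.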